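Inverting the saturated ring stereocentre of compound 2

The source may report more compounds than this note shows. Statements on the series, on what has been measured and on what is new or still open speak of the compounds shown alone.

Two compounds of the series have so far been run in an ADME assay on microsomes from liver (Homo sapiens) for metabolic stability, read by LC-MS, using NADPH, with a stated time of 30 min, tested at 0.1 uM, in the presence of a further agent that is not named here; a lower number here means that less of the compound is left, a higher number that more of the compound is left. Compound 1, `Nc1ccc(-c2cnc(N)c(-c3ccc(N)nc3)n2)cn1`, sits at the limit of this assay: compound 1 gives > 90%, a limit rather than a number. Compound 2, `Nc1ncc(-c2ccc(C(=O)N3CC[C@H](O)C3)cc2)nc1-c1ccc(C(F)(F)F)cc1`, likewise sits at the limit: in this assay compound 2 gives > 90%, again a limit and not a number. For the measured compounds named here, compound 2 thus stands at the top of what this assay reports, and with only limits in hand no step between the measured compounds can be read off (the limit of > 90% in this assay, at which 2 of the 2 values shown sit).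

Compound 3, `Nc1ncc(-c2ccc(C(=O)N3CC[C@@H](O)C3)cc2)nc1-c1ccc(C(F)(F)F)cc1`, has not yet been measured in this assay. It differs from compound 2 as follows: the two compounds have the same atoms and bonds and differ only in configuration as drawn: 1 of 1 stereo elements differ; a stereocentre at a saturated ring carbon is drawn S in compound 2 and R in compound 3. Going by the values given here, no step between measured compounds is available for this change, and no atom or bond leaves or enters. For a difference confined to the configuration at one saturated ring carbon, no step beyond the scatter of this assay is expected. Compound 3 is accordingly estimated at 95% in this assay, with a range from 88% to 100%, most likely reported again as a limit. The step this estimate means, a step that the limit leaves unreadable from compound 2 to compound 3, is expected to be none beyond the scatter.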

Compound 3, percent of the compound remaining: > 90%
Compound 3 gave a limit, no number; the forecaster's own chance of this, stated with the estimate: 85%; the middle value lies beyond the limit too.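

For the compounds shown here, no step from compound 2 to compound 3 can be read in this assay, because both compounds give a limit and not a number: the limit of > 90% in this assay, at which 3 of the 3 values shown sit. The compounds shown leave open whether the configuration at the saturated ring carbon makes any difference to the percent of the compound remaining.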